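The compounds below may be only part of what the source reports. "The series", "measured", "known", "first", "only" and "open" are said of these compounds alone.

Compound 1 `CCCc1cc(CNC(=O)c2cc3nc(C)c([C@H](OC(C)(C)C)C(=O)O)c(-c4cc(F)c5c(c4C)CCCO5)n3n2)ccc1F`: in an ADME assay on MT2 cells (Homo sapiens) for cytotoxicity (a lower number here means that less compound is tolerated, a higher number that more compound is tolerated), compound 1 gives > 20000 nM, which is a limit of the assay and not a number.
Compound 2 `COc1cc(F)ccc1CNC(=O)c1cc2nc(C)c([C@H](OC(C)(C)C)C(=O)O)c(-c3cc(F)c4c(c3C)CCCO4)n2n1`: in this assay compound 2 gives > 40000 nM, again a limit.
Compound 3 `Cc1nc2cc(C(=O)NCc3ccc(F)cc3S(C)(=O)=O)nn2c(-c2cc(F)c3c(c2C)CCCO3)c1[C@H](OC(C)(C)C)C(=O)O`: in this assay compound 3 gives > 40000 nM, also a limit.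

The three compounds share one core and differ only in the group on the saturated chain carbon bound to the amide-type nitrogen. For the measured compounds named here, compound 3 stands at a limit, and the two other values are limits as well, so no compound can be ranked against another. The three steps among them, a step that the two limits leave unreadable from compound 1 to compound 2, a step that the two limits leave unreadable from compound 1 to compound 3 and a step that the two limits leave unreadable from compound 2 to compound 3, cannot be read in size, since the limit of > 20000 nM in this assay, at which 1 of the 3 values shown sits, and the limit of > 40000 nM in this assay, at which 2 of the 3 values shown sit, mark the edges of what the assay reports.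

Compound 4 `Cc1nc2cc(C(=O)NCc3ccc(F)cc3-n3cncn3)nn2c(-c2cc(F)c3c(c2C)CCCO3)c1[C@H](OC(C)(C)C)C(=O)O` differs from compound 3 by 1H-1,2,4-triazol-1-yl in place of methylsulfonyl on an aromatic carbon. Going by the values given here, no measured step gives a readable size, so the expectation is that a number no higher from compound 3 to compound 4 (the limit leaves the size open) stays within the scatter, with no direction that can be called. Compound 4 is therefore expected to give about 40000 nM in this assay, in the range 20000 nM to 80000 nM, most likely again reported only as a limit.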

Compound 4, half-maximal cytotoxic concentration: > 40000 nM
Compound 4 gave a limit, no number; the forecaster's own chance of this, stated with the estimate: 85%; the middle value lies on the limit itself.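

In this assay compound 4 gives > 40000 nM, again a limit of the assay and not a number. Its steps to compound 1, compound 2 and compound 3 therefore cannot be read in size. The compounds shown leave open the concentration at which any of them harms these cells, and whether the differing group changes that concentration.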